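Pentyl removed from selenium: expected growth inhibition of compound 4

The source may hold more compounds than are shown below. What is called first, only, known or untested is meant among the compounds shown, and "the series" means these compounds.

Measured so far:
compound 1, `CSc1ccc(CNc2nc([SeH])nc3ccccc23)cc1`: > 100000 nM
compound 2, `Sc1nc(NCc2ccccc2)c2ccccc2n1`: > 100000 nM
compound 3, `CCCCC[Se]c1nc(NCc2ccccc2)c2ccccc2n1`: 47100 nM

Within the data shown here, in a functional assay on MCF7 cells (Homo sapiens) for cytotoxicity, read by MTT assay, with a stated time of 72 h (a lower number here means a stronger inhibitor of growth, a higher number a weaker inhibitor of growth), compound 3 carries the only number; compound 1 sits at a limit of the assay, and compound 2 sits at a limit too. Among the measured compounds shown here, the one measured step is an at least 2.1-fold lower number from compound 2 to compound 3 (0.32 log units; beyond the scatter), which put the pentylselenyl compound below the limit. Compound 4, `[SeH]c1nc(NCc2ccccc2)c2ccccc2n1`, differs from compound 3 by hydrogen in place of pentyl on a selenium. This undoes the change that gave the step from compound 2 to compound 3, with selenium instead of sulfur, and compound 1, which also bears hydrogen on selenium, sits at the limit of > 100000 nM in this assay, at which 2 of the 3 values shown sit. A rise beyond the scatter is therefore expected, most likely back to that limit. Compound 4 is estimated at 150000 nM, within 60000 nM to 400000 nM, an expected step of a 3.2-fold higher number from compound 3 to compound 4 (0.50 log units; beyond the scatter).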

Compound 4, concentration for total growth inhibition: > 100000 nM
Compound 4: only a limit was reported; the forecaster's own chance of this, stated with the estimate: 80%; the middle value does not contradict the limit.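

With pentyl on the selenium removed, this assay gives an at least 2.1-fold higher number from compound 3 to compound 4 (0.32 log units; beyond the scatter), so the measurable growth inhibition of compound 3 depends on the pentyl group and not on selenium alone. Compound 4 joins the compounds at the assay limit: the limit of > 100000 nM in this assay, at which 3 of the 4 values shown sit. The steps to compound 4 from compound 1 and compound 2 cannot be read, as both ends are limits, so any difference between selenium and sulfur stays hidden. Still open, on these data alone, are how pentyl on sulfur would compare with compound 3, and how a longer chain or one ending in an amine would read on the selenium.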